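Cytotoxicity in HEL cells: a carbamoyl added to compound 1

The source may report more compounds than this note shows. Statements on the series, on what has been measured and on what is new or still open speak of the compounds shown alone.

Three compounds have been measured in a functional assay on HEL cells (Homo sapiens) for cytotoxicity, read by microscopy; a higher number here means that more compound is tolerated, a lower number that less compound is tolerated:
- compound 1 `Cc1cn([C@@H]2O[C@H](CO[Si](C)(C)C(C)(C)C)[C@@]3(OS(=O)(=O)C=C3NCC(=O)O)[C@H]2O[Si](C)(C)C(C)(C)C)c(=O)n(C)c1=O` gives 300000 nM
- compound 2 `COC(=O)CNC1=CS(=O)(=O)O[C@@]12[C@@H](CO[Si](C)(C)C(C)(C)C)O[C@@H](n1cc(C)c(=O)n(C)c1=O)[C@@H]2O[Si](C)(C)C(C)(C)C` gives >= 400000 nM, which is a limit of the assay and not a number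
- compound 3 `Cc1cn([C@@H]2O[C@H](CO[Si](C)(C)C(C)(C)C)[C@@]3(OS(=O)(=O)C=C3NC(N)=O)[C@H]2O[Si](C)(C)C(C)(C)C)c(=O)n(C)c1=O` gives 16000 nM

Compound 1 stands highest of the two numbers shown; compound 3 sits below it by a 19-fold lower number from compound 1 to compound 3 (1.27 log units; beyond the scatter). Compound 4 `Cc1cn([C@@H]2O[C@H](CO[Si](C)(C)C(C)(C)C)[C@@]3(OS(=O)(=O)C=C3NCC(=O)C(N)=O)[C@H]2O[Si](C)(C)C(C)(C)C)c(=O)n(C)c1=O` differs from compound 1 by carbamoyl in place of hydroxy on a carbonyl carbon. Going by the values given here, two measured steps bear on this. The step of an at least 1.3-fold higher number from compound 1 to compound 2 (0.12 log units; that floor lies within the scatter), methyl in place of hydrogen, changed little. The step of a 19-fold lower number from compound 1 to compound 3 (1.27 log units; beyond the scatter), carbamoyl in place of carboxymethyl on an amine nitrogen, was large and downward. Compound 4 keeps the chain of compound 1 and gains a carbamoyl. The expected step is a 3.0-fold lower number from compound 1 to compound 4 (0.48 log units; beyond the scatter), moderate and downward. Compound 4 is therefore estimated at 100000 nM, within 30000 nM to 400000 nM.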

Compound 4, minimum cytotoxic concentration: >= 16000 nM
Compound 4: no number, only a limit (the forecaster's own chance of this, stated with the estimate: 15%); the middle value does not contradict the limit.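

In this assay compound 4 gives >= 16000 nM, which is a limit of the assay and not a number. Even so, the limit fixes a direction for the change on the amine nitrogen: a number no lower from compound 3 to compound 4 (the limit leaves the size open). From the compounds shown here alone, the steps linking compound 4 to compound 1 and to compound 2 cannot be read, so the effect of carbamoyl in place of hydroxy on a carbonyl carbon remains unknown.

The compounds shown leave open how far the value of compound 4 lies from that of compound 3. A carbamoylmethyl group or a longer chain ending in an amine on that nitrogen would give further points of comparison.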